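This account rests on a few compounds, and the source may have more. Where it says the series, first, only, none or still open, it means among the compounds named here.

Measured in a functional assay on MCF7 cells (Homo sapiens) for inhibition, with a stated time of 96 h; on this read-out lower numbers stand for stronger inhibition and higher numbers for weaker inhibition:
Compound 1 `COc1cc(C(=O)c2cn(-c3ccc(C)cc3)cc2-c2ncco2)cc(OC)c1OC`: 42 nM
Compound 2 `COc1cc(C(=O)c2cn(-c3ccc(F)cc3)cc2-c2ncco2)cc(OC)c1OC`: 93 nM

Of these two compounds, compound 1 has the lower number and so the stronger inhibition. Compound 3 `COc1cc(C(=O)c2cn(-c3ccc(C)cc3)cc2-c2cccnc2)cc(OC)c1OC` keeps the 4-methylphenyl group of compound 1 but carries pyridin-3-yl in place of 1,3-oxazol-2-yl on an aromatic carbon. Going by the values given here, the only measured step, a 2.2-fold higher number from compound 1 to compound 2 (0.35 log units; beyond the scatter), is modest and comes from fluoro in place of methyl on an aromatic carbon, at a different place in the molecule. Among the compounds with values here, it offers only a rough scale for one single change, and no measured compound carries pyridin-3-yl. A small move toward a higher number is therefore expected in this assay, though the direction is loosely held. The expected step is a 1.7-fold higher number from compound 1 to compound 3 (0.22 log units; within the scatter). For compound 3 the estimated value is 70 nM, with an expected range of 15 nM to 300 nM.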

Compound 3, half-maximal inhibitory concentration: 19 nM
Compound 3: the middle estimate sits 3.7-fold (0.57 log units) above what was measured; the range from low to high includes it.
By their numbers in this assay, from the lowest: compound 3; then compound 1; then compound 2.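

The earlier compounds shown here varied only the substituent on the 4-methylphenyl group; this result shows that the place two ring bonds from the ring nitrogen, which held 1,3-oxazol-2-yl in compound 1, also shifts the number in this assay (a 2.2-fold lower number from compound 1 to compound 3 (0.34 log units; beyond the scatter)). The shift runs toward stronger inhibition, so at this place 1,3-oxazol-2-yl is not required for inhibition on the scale of compound 1, and a six-membered aromatic ring with 1 hetero atom can take its position. Nothing available explains why the pyridin-3-yl compound reads lower.

The compounds shown leave open whether the ring nitrogen of pyridin-3-yl matters, since a plain phenyl ring or pyridin-4-yl at this place would test that. They also leave open whether the same exchange gives a similar step when fluoro stands in place of methyl.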